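Clearance notes on the step to compound 3

A few compounds are considered here, and "the series" means these few. Any claim that something is new, unique, unknown or untested is made for them only; others in the source may bear on it.

In an ADME assay (liver) for pharmacokinetics, with Liver microsome (Rattus norvegicus) as the target, read by LC-MS, using microsomes, tested at 2 uM (a lower number here means slower removal, a higher number faster removal of the compound), compound 1 `O=C(N[C@@H]1CCCC[C@H]1O)c1cnc(OC2CCC2)c(-c2ccc(Cl)cc2)c1` gives 0.21 mL/min/kg. Among the compounds with values here, compound 2 `O=C(N[C@@H]1CCCC[C@H]1O)c1cnc(OCc2ccccn2)c(-c2ccc(Cl)cc2)c1` gives 0.044 mL/min/kg, the lower of the two numbers so far and beyond the scatter from compound 1.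

Compound 3 `CN(CC1CC1)c1ncc(C(=O)N[C@@H]2CCCC[C@H]2O)cc1-c1ccc(Cl)cc1` keeps the shared core and changes one group: (cyclopropylmethyl)(methyl)amino in place of (pyridin-2-yl)methoxy on an aromatic carbon. In words, (cyclopropylmethyl)(methyl)amino stands in place of (pyridin-2-yl)methoxy on an aromatic carbon next to the ring nitrogen.

Within the data shown here, one measured step bears on this position: a 4.8-fold lower number from compound 1 to compound 2 (0.68 log units; beyond the scatter), a modest move that came with (pyridin-2-yl)methyl entering in place of cyclobutyl. Among the measured compounds shown here, compound 3 gives up that pyridine-bearing group and also puts a nitrogen where the oxygen stood, and no measured pair covers that second change. With a single step as a guide, a move of similar size in the opposite direction is expected, so the number should rise in this assay. The expected move is a 3.9-fold higher number from compound 2 to compound 3 (0.59 log units; beyond the scatter), probably beyond the scatter. For compound 3 the estimate is 0.17 mL/min/kg, with an expected range of 0.05 mL/min/kg to 0.6 mL/min/kg.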

Compound 3, clearance: 1.73 mL/min/kg
The estimate for compound 3 lay 10-fold (1.01 log units) below the measured number, and the stated range ends below it.
By their numbers in this assay, from the lowest: compound 2; then compound 1; then compound 3.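

In this assay, the aromatic carbon next to the ring nitrogen proves more sensitive than the earlier pair showed: (cyclopropylmethyl)(methyl)amino in place of (pyridin-2-yl)methoxy comes with a 39-fold higher number from compound 2 to compound 3 (1.59 log units; beyond the scatter), a large step. The same group in place of cyclobutyloxy comes with an 8.2-fold higher number from compound 1 to compound 3 (0.92 log units; beyond the scatter), so compound 3 stands above both compounds that carry an oxygen on this carbon, not only above the one with the pyridine ring. Nothing at hand accounts for either rise.

The compounds shown leave open how much of the change goes with the nitrogen replacing the oxygen on the aromatic carbon and how much with the groups attached to it, as compound 3 differs in both at once. A cyclopropylmethoxy group or a (pyridin-2-yl)methylamino group at this same place would separate the two, the first keeping the oxygen with a cyclopropyl-bearing chain and the second keeping the pyridine ring on a nitrogen.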